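Aminopyrimidine series: cytotoxicity note on the chloro analogue

The source may hold more compounds than are shown below. What is called first, only, known or untested is meant among the compounds shown, and "the series" means these compounds.

Measured compounds:
- compound 1, `CN1CCN(c2ccc(-c3cc(-c4ccc(C5NC(=O)c6ccccc6N5)cc4)nc(N)n3)cc2)CC1`, 10200 nM
- compound 2, `CC(C)(C)n1nnnc1C(c1ccc(C2NC(=O)c3ccccc3N2)cc1)N1CCc2ccccc2C1`, "not determined" (no result reported)

For the measured compounds named here, in an ADME assay on J774.A1 cells (Mus musculus) for cytotoxicity, read by MTT assay, with a stated time of 72 h (on this read-out lower numbers stand for higher toxicity in this test and higher numbers for lower toxicity in this test), compound 1 gives 10200 nM; this is the only number in the set, since compound 2 carries "not determined" (no result reported) here, so compound 1 stands alone and no order among measured compounds can be drawn.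

Compound 3, `Nc1nc(-c2ccc(Cl)cc2)cc(-c2ccc(C3NC(=O)c4ccccc4N3)cc2)n1`, is the untested member. It differs from compound 1 by a single exchange: chloro in place of 4-methylpiperazin-1-yl on an aromatic carbon. The replacing group sits on an aromatic carbon of a six-membered aromatic ring of carbon only, para to a large group, and the shared core of compound 1 is otherwise kept.

Going by the values given here, no pair of measured compounds shows the effect of any such exchange, so there is no measured step to lean on. The working expectation for compound 3 is a step from compound 1 that stays close to the usual scatter, with a slight lean toward a lower number, so that a 1.4-fold lower number from compound 1 to compound 3 (0.13 log units; within the scatter) is the expected move. Compound 3 is therefore estimated at 7500 nM, within the range 3000 nM to 25000 nM.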

Compound 3, half-maximal cytotoxic concentration: 82200 nM
Estimate against measurement, compound 3: 11-fold (1.04 log units) below, outside the stated range (above it).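

In this assay the place on an aromatic carbon of a six-membered aromatic ring of carbon only, para to a large group, proves not to be neutral: chloro in place of 4-methylpiperazin-1-yl gives an 8.1-fold higher number from compound 1 to compound 3 (0.91 log units; beyond the scatter) and so moves the read-out beyond the scatter. On this one pair, the compound carrying the 4-methylpiperazin-1-yl group is the more toxic in this test, and the compound carrying chloro is the less toxic, so the group at this place can set the cytotoxicity read-out of the shared core. No measurement shown accompanies the step, so nothing here accounts for it.

The compounds shown leave open whether a morpholin-4-yl or a dimethylamino group at the same place would keep the number close to compound 1 or carry it toward compound 3, and whether a fluoro or a methoxy group would fall near chloro. As far as these compounds go, with a single pair and a single read-out, it also stays open whether a step of this size would recur on any other core.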